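Dimethylamino for Methoxy on Two Ketone Cores

This account rests on a few compounds, and the source may have more. Where it says the series, first, only, none or still open, it means among the compounds named here.

Compound 1 `COc1ccc(/C=C2\CCCc3ccccc3C2=O)cc1` carries a methoxy group, and in a functional assay on CCRF-CEM cells (Homo sapiens) for inhibition (on this read-out higher numbers stand for weaker inhibition and lower numbers for stronger inhibition), compound 1 gives 350 nM. Compound 2 `CN(C)c1ccc(/C=C2\CCCc3ccccc3C2=O)cc1` differs from it by dimethylamino in place of methoxy on an aromatic carbon, and in this assay compound 2 gives 3050 nM, so that an 8.7-fold higher number from compound 1 to compound 2 (0.94 log units; beyond the scatter). Compound 3 `COc1ccc(/C=C2\CCCCCC2=O)cc1` keeps the methoxy group on another core; the difference between the two cores is not broken down here. In this assay compound 3 gives 194000 nM, the highest of the three numbers. Compound 4 `CN(C)c1ccc(/C=C2\CCCCCC2=O)cc1` has not yet been measured and differs from compound 3 by dimethylamino in place of methoxy on an aromatic carbon. This is the same kind of change as from compound 1 to compound 2, although the surroundings differ: in compound 1 the group sits para to a large group, in compound 3 para to a group of 9 heavy atoms. For the measured compounds named here, with only one earlier step to go on, compound 4 is expected to show a step of a 5.2-fold higher number from compound 3 to compound 4 (0.71 log units; beyond the scatter), because an 8.7-fold higher number from compound 1 to compound 2 (0.94 log units; beyond the scatter). The estimate for compound 4 is therefore 1000000 nM, with a likely range from 250000 nM to 4000000 nM, and a number this high may well come back as a limit rather than a value in this assay.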

Compound 4, half-maximal inhibitory concentration: 45100 nM
For compound 4 the middle estimate is 22-fold (1.35 log units) above the measured one; the measured number lies below the stated range.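

In this assay, dimethylamino in place of methoxy gives a 4.3-fold lower number from compound 3 to compound 4 (0.63 log units; beyond the scatter), so the same change runs in opposite directions on the two cores, and the steps differ in direction as well as in size: the same change on two cores in this assay, an 8.7-fold higher number (0.94 log units; beyond the scatter) from compound 1 to compound 2 and a 4.3-fold lower number (0.63 log units; beyond the scatter) from compound 3 to compound 4, 37-fold (1.57 log units) apart, beyond the scatter of two such steps In this series, then, the step found on the core of compound 1 cannot be carried over to the core of compound 3, and the effect of this change has to be read on each core separately. For the compounds shown here, with only one pair of compounds on each core, the two steps do not show why the cores respond differently, nor whether a third core would follow either of them.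

The compounds shown leave open how other groups in the same place would behave on these two cores, such as a hydroxy group, a chlorine atom or a piperidine ring. They also leave open whether a smaller amine, such as a methylamino or a plain amino group, would follow the step seen on the core of compound 1 or the one seen on the core of compound 3.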